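From 4-fluorophenyl to 2-methylphenyl on the amide nitrogen

This account rests on a few compounds, and the source may have more. Where it says the series, first, only, none or still open, it means among the compounds named here.

Values so far in a physicochemical assay for lipophilicity, read by mass spectrometry (on this read-out higher numbers stand for higher lipophilicity and lower numbers for lower lipophilicity), are:
- compound 1 `COc1cc2c(cc1OC)C(=O)C(C(=O)Nc1ccc(F)cc1)C2` gives 2.36
- compound 2 `CCOc1cccc(NC(=O)C2Cc3cc(OC)c(OC)cc3C2=O)c1` gives 2.42

Compound 1 lies within the scatter of compound 2, so these two numbers set no order. Compound 3 `COc1cc2c(cc1OC)C(=O)C(C(=O)Nc1ccccc1C)C2` is still to be measured in this assay and differs from compound 1 by one change (2-methylphenyl in place of 4-fluorophenyl on an amide-type nitrogen), with 2-methylphenyl in place of 4-fluorophenyl on an amide-type nitrogen. Going by the values given here, no measured pair shows a step for a single change, so direct support is lacking. Among the compounds with values here, the only guide is the closeness of compound 1 (2.36) and compound 2 (2.42). No move beyond the scatter is therefore expected, in either direction. The step expected in this assay is a number 0.09 log units higher from compound 1 to compound 3 (within the scatter) and it stays inside the scatter. Compound 3 is expected at 2.45 (estimated range 2.1 to 2.8).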

Compound 3, partition coefficient: 2.69
Compound 3: middle estimate off by 0.24 log units, on the low side, within the range that was stated.
By their numbers in this assay, from the lowest: compounds 1, 2 and 3 (each within the scatter of the next, the first and the last beyond it).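

In this assay, going by these compounds alone, 2-methylphenyl in place of 4-fluorophenyl on the amide-type nitrogen gives the first single-change step, a number 0.33 log units higher from compound 1 to compound 3 (beyond the scatter), so the aryl group at this position can move the number beyond the scatter, though only modestly. The two groups match in heavy-atom count, in their six-membered aromatic ring of carbon only and in their donor and acceptor counts, so none of these counts separates them. No measurement on hand bears on what lies behind this step.

Going by these compounds, what the loss of fluorine and the gain of methyl each contribute remains open, and a plain phenyl or a 4-methylphenyl on the same nitrogen would separate the two. Also open, on these data alone, is how this assay responds at this position to an aryl group carrying an amine or a carboxylic acid.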